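The source may report more compounds than this note shows. Statements on the series, on what has been measured and on what is new or still open speak of the compounds shown alone.

Working notes on the series.

Compound 1 `COc1ccc(-n2c(SC(C)C(=O)Nc3cc(Br)ccc3Br)nc3ccccc32)cc1` carries the shared core with a dibromophenyl amide; in an ADME assay on Vero cells (Chlorocebus sabaeus) for cytotoxicity, read by MTT assay, with a stated time of 24 h (on this read-out lower numbers stand for higher toxicity in this test and higher numbers for lower toxicity in this test), compound 1 gives "not determined" (no result reported), so it gives no number to compare. Within the data shown here, compound 2 `COc1ccc(-n2c(SC(C)C(=O)Nc3ncc(C)cc3Cl)nc3ccccc32)cc1` is the one member with a measured figure: in this assay compound 2 gives 880 nM. It therefore stands alone on the numbers shown, with no second measured compound to set a step against.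

Compound 3 `COc1ccc(-n2c(SC(C)C(=O)Nc3nc(C)c(Cl)cc3Cl)nc3ccccc32)cc1` differs from compound 2 in one place: 3,5-dichloro-6-methylpyridin-2-yl in place of 3-chloro-5-methylpyridin-2-yl on an amide-type nitrogen. Among the measured compounds shown here, no step between measured compounds is available to show how a change on this amide-type nitrogen moves the read-out in this assay. For the measured compounds named here, with nothing to go on beyond the single figure of compound 2, the step from compound 2 to compound 3 is expected to stay within the usual scatter, a 1.2-fold lower number from compound 2 to compound 3 (0.07 log units; within the scatter), with no clear direction. Compound 3 is estimated at 750 nM, in the range 300 nM to 2000 nM.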

Compound 3, half-maximal cytotoxic concentration: 7250 nM
Compound 3: middle estimate off by 9.7-fold (0.99 log units), on the low side, outside the stated range (above it).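

In this assay the group on the amide-type nitrogen proves able to move the read-out: 3,5-dichloro-6-methylpyridin-2-yl in place of 3-chloro-5-methylpyridin-2-yl gives an 8.2-fold higher number from compound 2 to compound 3 (0.92 log units; beyond the scatter), a step towards lower toxicity in this test that the single earlier figure could not reveal. The change is a double one, with a second chlorine added and the methyl named at 6 rather than 5, so this step cannot assign the shift to either part. Nothing available explains the shift.

The steps to the dibromophenyl amide of compound 1 cannot be read, since compound 1 gives "not determined" (no result reported). Open too, from the compounds shown here alone, are the effect of the second chlorine without the methyl change, and what an amine or a carboxylic acid on the pyridine ring in place of chlorine would give.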